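This account rests on a few compounds, and the source may have more. Where it says the series, first, only, none or still open, it means among the compounds named here.

In a functional assay on the whole organism with Rattus norvegicus as the target (a higher number here means that more compound is needed for the effect, a lower number that less compound is needed), the three measured compounds gave these doses:

Compound 1 `CC1CCC(/C=N/c2ccccc2O)=C2NC=C(C(=O)O)C(=O)N21`: 4.11 umol/kg
Compound 2 `Cc1cccc(/N=C/C2=C3NC=C(C(=O)O)C(=O)N3C(C)CC2)c1`: 0.8 umol/kg
Compound 3 `Cc1ccc(/N=C/C2=C3NC=C(C(=O)O)C(=O)N3C(C)CC2)cc1`: 3.6 umol/kg

Compound 3 stands second highest of the three. Its nearest neighbour is compound 1, whose value lies within the scatter of its own; compound 2 lies clearly apart, a 4.5-fold higher number from compound 2 to compound 3 (0.65 log units; beyond the scatter).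

Compound 4 `CC1CCC(/C=N/c2cccnc2)=C2NC=C(C(=O)O)C(=O)N21` differs from compound 3 in one place: pyridin-3-yl in place of 4-methylphenyl on a double-bonded nitrogen. Among the measured compounds shown here, no measured step swaps a carbon-only ring for a ring with a hetero atom, but every measured step alters the group on the double-bonded nitrogen: a 5.1-fold lower number from compound 1 to compound 2 (0.71 log units; beyond the scatter), a 1.1-fold lower number from compound 1 to compound 3 (0.06 log units; within the scatter) and a 4.5-fold higher number from compound 2 to compound 3 (0.65 log units; beyond the scatter). Changes there shifted this assay from not at all to modestly, so compound 4 is expected close to compound 3, with a 1.1-fold higher number from compound 3 to compound 4 (0.05 log units; within the scatter) expected to lie within the scatter or only slightly beyond it. Compound 4 is therefore estimated at 4 umol/kg, in the range 1.5 umol/kg to 12 umol/kg.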

Compound 4, dose for 50% inhibition: 2.4 umol/kg
Estimate against measurement, compound 4: 1.7-fold (0.22 log units) above; low and high end bracket the measured number.
By their numbers in this assay, from the lowest: compound 2; then compounds 4, 3 and 1 (each within the scatter of the next).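

On a double-bonded nitrogen, a six-membered aromatic ring with a hetero atom is tolerated in this assay: pyridin-3-yl gives a 1.5-fold lower number from compound 3 to compound 4 (0.18 log units; within the scatter) and a 1.7-fold lower number from compound 1 to compound 4 (0.23 log units; within the scatter), so these three compounds cannot be told apart. Among the compounds shown here, compound 2 still stands apart, with a 3.0-fold higher number from compound 2 to compound 4 (0.48 log units; beyond the scatter), and 3-methylphenyl remains the only group here that gives a clearly lower number.

Going by these compounds, whether a pyridin-4-yl group or a phenyl ring carrying an amine would reach the level of compound 2 remains open. Why the numbers fall this way is also open, as no measurement shown here bears on it.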